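The source may report more compounds than this note shows. Statements on the series, on what has been measured and on what is new or still open speak of the compounds shown alone.

Compound 1 `Cc1ccc(-n2nc(-c3ccccc3)nc2CNc2ccc(C(=O)NO)cc2)cc1` was tested in an assay on Sf9 cells for inhibition of protein deacetylase HDAC6 (Homo sapiens), read by fluorescence, with a stated time of 40 min, tested at 100 nM (a lower number here means less inhibition, a higher number more inhibition at the concentration tested (going by the name of the read-out)), where compound 1 gives 60.7%. Its companion, compound 2 `O=C(NO)c1ccc(NCc2nc(-c3ccc(Cl)c(Cl)c3)nn2-c2ccccc2)cc1`, gives 34.5% in this assay, so compound 1 stands higher of the two numbers measured. Compound 3 `O=C(NO)c1ccc(NCc2nc(-c3ccccc3)nn2-c2ccccc2Cl)cc1` has not been measured; it differs from compound 1 by the change (2-chlorophenyl in place of 4-methylphenyl on an aromatic nitrogen). Among the measured compounds shown here, with no measured step of this kind to lean on, the expected step from compound 1 to compound 3 is a modest decrease, a number 10.7 percentage points lower from compound 1 to compound 3 (beyond the scatter), though one that could still fall within the scatter. Compound 3 is therefore estimated at 50%, with a range from 30% to 70%.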

Compound 3, a percentage reported as inhibition, at one concentration (the size of the read-out at that concentration, not a potency): 64.6%
For compound 3 the middle estimate is 14.6 percentage points below the measured one, within the range that was stated.
By their numbers in this assay, from the lowest: compound 2; then compounds 1 and 3 (each within the scatter of the next).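

Among the compounds shown here, on the aromatic nitrogen, 2-chlorophenyl in place of 4-methylphenyl gives a number 3.9 percentage points higher from compound 1 to compound 3 (within the scatter) in this assay and is the first step measured at this position. It shows that this place accepts a chlorine-bearing phenyl with a chlorine next to the ring's point of attachment and a methyl group removed, with no change beyond the scatter. No available evidence bears on this result. The compounds shown leave open how 4-chlorophenyl would compare with 2-chlorophenyl here. They also leave open how a phenyl bearing an amine or a carboxylic acid would fare on this nitrogen.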